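Amino in Place of Phenyl on a Shared Core

The compounds below may be only part of what the source reports. "The series", "measured", "known", "first", "only" and "open" are said of these compounds alone.

Measured compounds:
compound 1, `CN(C)c1c(C#N)c2c(N)ncnc2n1C`, 3760 nM
compound 2, `Cn1c(NCc2ccccc2)c(C#N)c2c(N)ncnc21`, 3530 nM
compound 3, `Cn1c(-c2ccccc2)c(C#N)c2c(N)ncnc21`, 483 nM

All three were tested in an assay on isolated protein for inhibition of Leucine-rich repeat serine/threonine-protein kinase 2 variant G2019S (Homo sapiens), read by TR-FRET and LanthaScreen, with stated times of 50 min and 30 min, in the presence of a further agent that is not named here; on this read-out higher numbers stand for weaker inhibition and lower numbers for stronger inhibition. Compound 3 stands lowest of the three numbers: compound 2 sits a good way higher, and compound 1 higher still, both gaps beyond the scatter. Within the data shown here, the one single-point step among the measured compounds runs from the dimethylamino of compound 1 to the phenyl of compound 3, a 7.8-fold lower number from compound 1 to compound 3 (0.89 log units; beyond the scatter).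

Compound 4, `Cn1c(N)c(C#N)c2c(N)ncnc21`, is not yet measured. It differs from compound 3 in one place: amino in place of phenyl on an aromatic carbon. Among the measured compounds shown here, the relevant measured step is the one from compound 1 to compound 3, which traded a nitrogen substituent for phenyl and brought the number down; the present change runs the other way, removing the phenyl and putting a nitrogen substituent back. Compound 2, bearing benzylamino at the same place, also gave a number well above compound 3. A rise in this assay is therefore expected for compound 4, of roughly the size seen in that step, run the other way. The expected step for compound 4 is a 6.2-fold higher number from compound 3 to compound 4 (0.79 log units; beyond the scatter). Compound 4 is estimated at 3000 nM, with a range from 1000 nM to 9000 nM.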

Compound 4, half-maximal inhibitory concentration: 8560 nM
Beside the measured number, compound 4's estimate is 2.9-fold (0.46 log units) below it; low and high end bracket the measured number.
By their numbers in this assay, from the lowest: compound 3; then compounds 2 and 1 (each within the scatter of the next); then compound 4.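

Compound 4 shows that in this assay a bare amino on this aromatic carbon is a poor replacement for phenyl, with an 18-fold higher number from compound 3 to compound 4 (1.25 log units; beyond the scatter) on this change, a larger step than the earlier nitrogen substituents had shown against phenyl. It also shows that what the nitrogen carries matters at this position: the number rises with a 2.4-fold higher number from compound 2 to compound 4 (0.38 log units; beyond the scatter) when benzyl gives way to hydrogen, and with a 2.3-fold higher number from compound 1 to compound 4 (0.36 log units; beyond the scatter) when amino replaces dimethylamino. Compound 4 therefore stands as the weakest of the four in this assay, while compounds 1 and 2, which stand within the scatter of each other, both keep a carbon group on the nitrogen and both remain well above compound 3.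

The compounds shown leave open whether a single methyl on the nitrogen, a cyclic amine such as morpholine, or a pyridine ring or fluorophenyl in place of phenyl would land nearer compound 3 or nearer compound 4. Nothing available bears on the reason for these steps, so the numbers stand here without an explanation.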